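Swapping an aryl group for tert-butyl in a pyrazole series

A few compounds are considered here, and "the series" means these few. Any claim that something is new, unique, unknown or untested is made for them only; others in the source may bear on it.

Compounds measured in an ADME assay on Huh-7 cells (Homo sapiens) for cytotoxicity; a lower number here means that less compound is tolerated, a higher number that more compound is tolerated:
- compound 1, `CN1CCN(CCNCc2cn(-c3ccc(F)cc3F)nc2-c2ccc(OC(F)(F)F)cc2)CC1`: 18000 nM
- compound 2, `Cc1cccc(-c2nn(-c3ccc(F)cc3F)cc2CNCCN2CCN(C)CC2)c1`: > 20000 nM, a limit of the assay
- compound 3, `COc1ccc(-c2nn(-c3ccc(F)cc3F)cc2CNCCN2CCN(C)CC2)cc1`: > 20000 nM, a limit of the assay

Compound 3 stands at the upper limit of this assay, so only a bound and no number is known for it; the same holds for compound 2, as the limit of > 20000 nM in this assay, at which 2 of the 3 values shown sit, records. Among the compounds with values here, compound 1 is the only one with a measured value, and the steps away from it are small: an at least 1.1-fold higher number from compound 1 to compound 2 (0.04 log units; that floor lies within the scatter) and an at least 1.1-fold higher number from compound 1 to compound 3 (0.04 log units; that floor lies within the scatter), both with a floor inside the scatter. The step that the two limits leave unreadable from compound 2 to compound 3 cannot be read at all.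

Compound 4, `CN1CCN(CCNCc2cn(-c3ccc(F)cc3F)nc2C(C)(C)C)CC1`, differs from compound 3 by tert-butyl in place of 4-methoxyphenyl on an aromatic carbon. Within the data shown here, none of the measured steps exchanges an aryl group for an alkyl group, so they bear on this change only loosely; what they show is that varying the group on this aromatic carbon has not moved this assay beyond its scatter so far. Compound 4 is therefore expected to sit near the limit again, with a step that the limit leaves unreadable from compound 3 to compound 4 not beyond the scatter. The estimate for compound 4 is 22000 nM, ranging from 9000 nM to 50000 nM.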

Compound 4, half-maximal cytotoxic concentration: > 20000 nM
Compound 4 was reported as a limit (the forecaster's own chance of this, stated with the estimate: 65%); the middle value does not contradict the limit.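

In this assay compound 4 gives > 20000 nM, which is a limit of the assay and not a number. This is the first compound shown with an alkyl group on this aromatic carbon, where tert-butyl, which has no ring, takes the place of the aryl groups, and the only step that can be read is an at least 1.1-fold higher number from compound 1 to compound 4 (0.04 log units; that floor lies within the scatter), while the steps to compound 4 from compound 2 and compound 3 cannot be read. An aromatic ring on this carbon is therefore not required for the compound to reach the limit, and the aryl and tert-butyl compounds now end up at the same bound, with compound 1 alone giving a measured value: the limit of > 20000 nM in this assay, at which 3 of the 4 values shown sit.

How far compound 2, compound 3 and compound 4 lie beyond that limit remains unknown, so the compounds shown give no order among them. Also open, on these data alone, is whether a carboxylic acid or a primary amine on this aromatic carbon, or a longer alkyl chain in place of tert-butyl, would give a measured value in this assay rather than a limit.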